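The source may report more compounds than this note shows. Statements on the series, on what has been measured and on what is new or still open speak of the compounds shown alone.

Compound 1 `Nc1nc(NCc2ccccc2)c2ncn(/C=C3/CC3(CO)CO)c2n1` gives 19900 nM in an ADME assay on BCBL1 cells (Homo sapiens) for cytotoxicity, with a stated time of 7 days (a higher number here means that more compound is tolerated, a lower number that less compound is tolerated), the lowest of the two numbers measured there. Compound 2 `Nc1nc(NC2CC2)c2ncn(/C=C3/CC3(CO)CO)c2n1` gives 71500 nM, a step that is a 3.6-fold higher number from compound 1 to compound 2 (0.56 log units; beyond the scatter). Compound 3 `CCCCOc1nc(N)nc2c1ncn2/C=C1/CC1(CO)CO` reaches only a limit of the assay, > 20000 nM. The change leading to compound 4 `CCCCSc1nc(N)nc2c1ncn2/C=C1/CC1(CO)CO` is butylsulfanyl in place of benzylamino on an aromatic carbon. The nearest measured comparison, a number no lower from compound 1 to compound 3 (the limit leaves the size open), leaves the size of the step open because of the limit of > 20000 nM in this assay, at which 1 of the 3 values shown sits, and the step of a 3.6-fold higher number from compound 1 to compound 2 (0.56 log units; beyond the scatter) also points toward a higher number when the benzylamino group is replaced. Compound 4 is therefore expected to sit at or above compound 1, with an estimated 30000 nM, in the range 10000 nM to 100000 nM, which corresponds to an expected 1.5-fold higher number from compound 1 to compound 4 (0.18 log units; within the scatter).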

Compound 4, half-maximal cytotoxic concentration: > 20000 nM
Compound 4 was reported as a limit; the forecaster's own chance of this, stated with the estimate: 50%; the middle value lies beyond the limit too.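

At this aromatic carbon, butylsulfanyl, which has no ring and no hydrogen-bond donor, also replaces benzylamino without lowering the number in this assay: a number no lower from compound 1 to compound 4 (the limit leaves the size open). The result for compound 4 is a limit, as is the result for compound 3, so swapping butoxy for butylsulfanyl adds a second limit rather than a size. The steps from compound 2 and compound 3 to compound 4 cannot be read because of this: the limit of > 20000 nM in this assay, at which 2 of the 4 values shown sit.

Where compound 3 and compound 4 truly stand remains open, so butoxy, butylsulfanyl and cyclopropylamino cannot be ranked. Going by these compounds, how a shorter chain such as methylsulfanyl, or a plain amino group, would behave at this carbon also stays open.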